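The source may report more compounds than this note shows. Statements on the series, on what has been measured and on what is new or still open speak of the compounds shown alone.

Measured in a physicochemical assay for lipophilicity, read by HPLC, at pH 7.5; on this read-out higher numbers stand for higher lipophilicity and lower numbers for lower lipophilicity:
- Compound 1 `CC[C@@H](Nc1c(C#N)c(-c2ccc(-c3cccc(C)c3)cc2)nc2cnccc12)C(N)=O`: 3
- Compound 2 `CC[C@@H](Nc1c(C#N)c(-c2ccc(-c3cccc(Cl)c3F)cc2)nc2cnccc12)C(N)=O`: 3.1
- Compound 3 `CCOc1ccccc1-c1ccc(-c2nc3cnccc3c(C[C@H](C)C(N)=O)c2C#N)cc1`: 3

In this assay, compound 3 gives 3, the same number at the digits shown as compound 1, and its value lies within the scatter of compound 2.

Compound 4 `CCOc1ccccc1-c1ccc(-c2nc3cnccc3c(N[C@H](CC)C(N)=O)c2C#N)cc1` departs from compound 3 at one place: (1-carbamoylpropyl)amino in place of 2-carbamoylpropyl on an aromatic carbon. The (1-carbamoylpropyl)amino group takes the place of 2-carbamoylpropyl on an aromatic carbon, ortho to a cyano group and opposite the ring nitrogen.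

For the measured compounds named here, no measured step makes this exchange directly. Going by the values given here, the only measured step, a number 0.10 log units higher from compound 1 to compound 2 (within the scatter), concerns a different group, 3-chloro-2-fluorophenyl in place of 3-methylphenyl, and so bears on the question only indirectly. More useful is that the entering group is already present in compound 1 at 3 and in compound 2 at 3.1. These numbers sit within the scatter of the value for compound 3, which carries the leaving group.

On these three compounds alone, no shift beyond the scatter is expected in this assay. The expected change is small: a number 0.10 log units higher from compound 3 to compound 4 (within the scatter). For compound 4 the estimated value is 3.1, with an expected range from 2.8 to 3.4.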

Compound 4, distribution coefficient: 3
The estimate for compound 4 lay 0.10 log units above the measured number, and the stated range covers the measured number.
By their numbers in this assay, from the lowest: compounds 1, 3, 4 and 2 (each within the scatter of the next).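

In this assay, the exchange at this position, on the aromatic carbon ortho to a cyano group and opposite the ring nitrogen, gives no change at the digits printed from compound 3 to compound 4 (within the scatter) when 2-carbamoylpropyl gives way to (1-carbamoylpropyl)amino, so the read-out does not separate the two groups on the 2-ethoxyphenyl background. For the compounds shown here, with (1-carbamoylpropyl)amino held in place, the earlier compounds gain a third aryl group: 2-ethoxyphenyl in place of 3-chloro-2-fluorophenyl gives a number 0.10 log units lower from compound 2 to compound 4 (within the scatter) and 2-ethoxyphenyl in place of 3-methylphenyl gives no change at the digits printed from compound 1 to compound 4 (within the scatter) in the same assay, so none of these three groups stands apart from the others. No independent evidence is available to explain why these exchanges leave the read-out unmoved.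

The compounds shown leave open whether a longer chain at this position, or a carboxylic acid in place of the carbamoyl group, would stay within the scatter in this assay as well. From the compounds shown here alone, they also carry 2-carbamoylpropyl only alongside 2-ethoxyphenyl, so it remains unknown whether the same exchange would read alike with 3-methylphenyl or 3-chloro-2-fluorophenyl.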